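Halopurine in place of thymine on the shared core

A few compounds are considered here, and "the series" means these few. Any claim that something is new, unique, unknown or untested is made for them only; others in the source may bear on it.

Compound 1 `Cc1cn(C2CN(S(=O)(=O)c3ccccc3[N+](=O)[O-])c3ccccc3CO2)c(=O)[nH]c1=O` is the weakest of the three compounds measured in a functional assay on MCF7 cells (Homo sapiens) for cytotoxicity, read by sulforhodamine B assay, with a stated time of 3 days (on this read-out higher numbers stand for weaker inhibition and lower numbers for stronger inhibition), where compound 1 gives 45200 nM. Compound 2 `O=[N+]([O-])c1ccccc1S(=O)(=O)N1CC(n2cnc3c(I)nc(Cl)nc32)OCc2ccccc21` gives 610 nM in this assay, and compound 3 `COC(CN(c1ccccc1CO)S(=O)(=O)c1ccc([N+](=O)[O-])cc1)n1cnc2c(Cl)nc(Cl)nc21`, built on a different core, gives 355 nM. Compound 4 `O=[N+]([O-])c1ccccc1S(=O)(=O)N1CC(n2cnc3c(Br)ncnc32)OCc2ccccc21` differs from compound 1 in one place: a group of 10 heavy atoms (5 carbon, 4 nitrogen, 1 bromine; one five-membered aromatic ring with 2 hetero atoms, one six-membered aromatic ring with 2 hetero atoms) in place of a group of 9 heavy atoms (5 carbon, 2 nitrogen, 2 oxygen; one six-membered aromatic ring with 2 hetero atoms), on a saturated ring carbon. Going by the values given here, the one measured step that bears on this change is the exchange of the same leaving group for a related halogenated pair of fused aromatic rings on the shared core, a 74-fold lower number from compound 1 to compound 2 (1.87 log units; beyond the scatter). The group entering compound 4 shares with the group entering compound 2 the five-membered aromatic ring fused to the six-membered aromatic ring and a halogen on that ring, but carries bromine instead of iodine and lacks the chlorine. A step of broadly comparable size in the same direction, toward lower numbers, is therefore expected, a 45-fold lower number from compound 1 to compound 4 (1.66 log units; beyond the scatter). Compound 4 is expected to give 1000 nM in this assay, with a range from 300 nM to 4000 nM.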

Compound 4, half-maximal inhibitory concentration: 3620 nM
Beside the measured number, compound 4's estimate is 3.6-fold (0.56 log units) below it; measured number inside the range.
By their numbers in this assay, from the lowest: compounds 3 and 2 (each within the scatter of the next); then compound 4; then compound 1.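

In this assay, the step toward lower numbers at this saturated ring carbon, next to the ring oxygen, holds for a second entering group with a five-membered and a six-membered aromatic ring: a 12-fold lower number from compound 1 to compound 4 (1.10 log units; beyond the scatter). The step is not the same for both such groups, since a 5.9-fold higher number from compound 2 to compound 4 (0.77 log units; beyond the scatter), so the outcome at this position depends on the halogens carried and not only on the two rings. No measurement at hand accounts for this difference.

Compound 2 and compound 4 differ in both the iodine or bromine and the chlorine, so the shown values cannot separate the share of each halogen. On these data alone, it remains open whether the lower numbers persist with an amine in place of the bromine of compound 4.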